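The compounds below may be only part of what the source reports. "The series", "measured", "known", "first", "only" and "open" are said of these compounds alone.

Measured in a functional assay on PC-3 cells (Homo sapiens) for inhibition, read by MTT assay, with stated times of 18 h and 4 h; on this read-out lower numbers stand for stronger inhibition and higher numbers for weaker inhibition:
- compound 1 `CCCCCCCCOP(=O)(O)OCCSC(=S)N1CCN(C)CC1`: > 100000 nM
- compound 2 `CCCCCCCCOP(=O)(O)OCCSC(=S)N1CCCCCC1`: 56800 nM

Compound 1 gives no number, only a limit: the limit of > 100000 nM in this assay, at which 1 of the 2 values shown sits. Compound 3 `CCCOP(=O)(O)OCCSC(=S)N1CCN(C)CC1` shortens its chain from octyl to propyl, which is hydrogen in place of pentyl on a saturated chain carbon, three bonds along the chain from an oxygen on an unsaturated carbon. Within the data shown here, the one measured step, an at least 1.7-fold lower number from compound 1 to compound 2 (0.24 log units; that floor lies within the scatter), changes the group on the thiocarbonyl carbon and leaves the chain untouched, so it sets no size for this change. In this assay the expected result is weak inhibition again, with a result at the limit most likely. The expected step is a step that the limit leaves unreadable from compound 1 to compound 3. For compound 3 the estimate is 150000 nM, with an expected range of 80000 nM to 400000 nM.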

Compound 3, half-maximal inhibitory concentration: > 100000 nM
Compound 3 ended at the assay's limit (the forecaster's own chance of this, stated with the estimate: 85%); the middle value lies beyond the limit too.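

Among these compounds, compound 1 and compound 3 both end at a limit rather than at a number, so no step between them can be read: the limit of > 100000 nM in this assay, at which 2 of the 3 values shown sit. As far as these compounds go, whether octyl and propyl chains differ at all in inhibition stays open.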